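A Pyridinyl Arm Added to the Weaker Inhibitor

This account rests on a few compounds, and the source may have more. Where it says the series, first, only, none or still open, it means among the compounds named here.

For the measured compounds named here, in an assay on COS-7 cells for inhibition of tyrosine-protein kinase receptor UFO (Homo sapiens), read by ELISA, with a stated time of 1 h (on this read-out higher numbers stand for weaker inhibition and lower numbers for stronger inhibition), compound 2 `Cc1cc(-c2c(C)nn(C)c2C)cnc1-c1nnc(N(C)Cc2ccc3nccn3c2)o1` gives 6310 nM, the highest of the two numbers measured so far, while compound 1 `COc1cc(-c2c(C)nn(C)c2C)ccc1-c1nnc(N(C)Cc2ccc3nccn3c2)o1` gives 2000 nM, a lower value beyond the usual scatter. Compound 3 `Cc1cc(-c2c(C)nn(C)c2C)cnc1-c1nnc(N(C)Cc2ccc3ncc(-c4ccc(CN(C)C)nc4)n3c2)o1` differs from compound 2 in one place: 6-((dimethylamino)methyl)pyridin-3-yl in place of hydrogen on an aromatic carbon. Going by the values given here, no measured pair shows the effect of such an addition, so the expectation rests on compound 2 alone. The change is expected to lower the number in this assay beyond the scatter, by a 5.3-fold lower number from compound 2 to compound 3 (0.72 log units; beyond the scatter). Compound 3 is estimated at 1200 nM, within a range from 300 nM to 5000 nM.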

Compound 3, half-maximal inhibitory concentration: 1580 nM
The estimate for compound 3 lay 1.3-fold (0.12 log units) below the measured number; measured number inside the range.
By their numbers in this assay, from the lowest: compounds 3 and 1 (each within the scatter of the next); then compound 2.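

In this assay the change to 6-((dimethylamino)methyl)pyridin-3-yl in place of hydrogen brings a 4.0-fold lower number from compound 2 to compound 3 (0.60 log units; beyond the scatter) and so shows that this aromatic carbon, next to the ring nitrogen, accepts a substituent of 10 heavy atoms without loss of inhibition. The earlier compounds shown here carry only hydrogen here, so they could not show this. No available measurement accounts for the drop in the number. The compounds shown leave open whether the pyridine ring or its dimethylaminomethyl arm carries the gain, and whether a plain phenyl ring or a morpholine in place of the dimethylamino group would do the same.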